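The source may hold more compounds than are shown below. What is called first, only, known or untested is meant among the compounds shown, and "the series" means these compounds.

Among the measured compounds shown here, compound 1 `COc1cc(-c2nnc3n2NC(c2ccco2)C(C(=O)c2ccc(F)c(F)c2)S3)cc(OC)c1OC` was tested in a functional assay on A549 cells (Homo sapiens) for cytotoxicity, read by MTT assay, with a stated time of 48 h (a lower number here means a stronger inhibitor, a higher number a weaker inhibitor), where compound 1 gives 93700 nM, the highest of the two numbers measured so far. Its nearest neighbour is compound 2 `COc1cc(-c2nnc3n2NC(c2ccco2)C(C(=O)c2ccc(C(F)(F)F)cc2)S3)cc(OC)c1OC`, which in this assay gives 37200 nM; the step of a 2.5-fold lower number from compound 1 to compound 2 (0.40 log units; beyond the scatter) comes from swapping the ring on the same carbonyl carbon. Compound 3 `COc1cccc(C(=O)C2Sc3nnc(-c4cc(OC)c(OC)c(OC)c4)n3NC2c2ccco2)c1` differs from compound 1 by 3-methoxyphenyl in place of 3,4-difluorophenyl on a carbonyl carbon. For the measured compounds named here, no measured step covers this exact swap, so only a small shift is expected, and compound 3 is estimated at 70000 nM, within 25000 nM to 200000 nM. The expected step is a 1.3-fold lower number from compound 1 to compound 3 (0.13 log units; within the scatter).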

Compound 3, half-maximal inhibitory concentration: > 100000 nM
Compound 3: only a limit was reported; the forecaster's own chance of this, stated with the estimate: 10%; at least 1.4-fold (0.15 log units) between middle value and limit.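

In this assay compound 3 yields only a limit of the assay, not a number: the limit of > 100000 nM in this assay, at which 1 of the 3 values shown sits.

The change to 3-methoxyphenyl on this carbonyl carbon gives an at least 2.6-fold higher number from compound 2 to compound 3 (0.42 log units; beyond the scatter), so a ring bearing a methoxy group reads clearly weaker than the 4-(trifluoromethyl)phenyl ring. Against the 3,4-difluorophenyl ring, the result gives only an at least 1.0-fold higher number from compound 1 to compound 3 (0.02 log units; that floor lies within the scatter), so no order can be stated for that pair. The compounds shown leave open how far past the limit compound 3 lies, and whether an amine or carboxylic acid on this ring, or an alkyl chain replacing it, would lower the number.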